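The compounds below may be only part of what the source reports. "The series", "measured", "known", "first", "only" and "open" are said of these compounds alone.

Measured so far:
compound 1 `Oc1ccc(-c2nc3cc(C(F)(F)F)ccc3[nH]2)cc1` — > 100000 nM
compound 2 `CCC(=O)Nc1ccc(-c2nc3cc(C(F)(F)F)ccc3[nH]2)cc1` — 100000 nM
compound 3 `CC(=O)Nc1ccc(-c2nc3ccccc3[nH]2)cc1` — > 100000 nM

In an ADME assay on BHK cells (Mesocricetus auratus) for cytotoxicity, read by MTT assay, with a stated time of 96 h (a lower number here means that less compound is tolerated, a higher number that more compound is tolerated), compound 3 gives only a limit, > 100000 nM, and not a number. The same limit, (the limit of > 100000 nM in this assay, at which 2 of the 3 values shown sit), is where compound 1 also sits. Compound 4 `CC(=O)Nc1ccc(-c2nc3cc(C(F)(F)F)ccc3[nH]2)cc1` differs from compound 3 in one place: trifluoromethyl in place of hydrogen on an aromatic carbon. No measured step covers this change; the only step shown, a number no higher from compound 1 to compound 2 (the limit leaves the size open), concerns a different place and leaves its size open. Compound 1, which carries the trifluoromethyl, gives only a limit, > 100000 nM. Compound 2, which also carries the trifluoromethyl, gives 100000 nM. In neither of them has the trifluoromethyl been seen to lower tolerance. Compound 4 is therefore expected to show no step beyond the scatter, a number no higher from compound 3 to compound 4 (the limit leaves the size open). For compound 4 the estimate is 100000 nM, within 40000 nM to 250000 nM, most likely reported again as a limit.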

Compound 4, half-maximal cytotoxic concentration: 53000 nM
Beside the measured number, compound 4's estimate is 1.9-fold (0.28 log units) above it, within the range that was stated.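

In this assay, the trifluoromethyl change on the aromatic carbon now has a step of its own, an at least 1.8-fold lower number from compound 3 to compound 4 (0.27 log units; that floor lies within the scatter), but its true size stays open, as values in this assay often stop at a limit: the limit of > 100000 nM in this assay, at which 2 of the 4 values shown sit.

Among the trifluoromethyl compounds, hydrogen in place of methyl on the chain gives a 1.9-fold lower number from compound 2 to compound 4 (0.28 log units; within the scatter), and acetamido in place of hydroxy gives an at least 1.8-fold lower number from compound 1 to compound 4 (0.27 log units; that floor lies within the scatter).

The compounds shown leave open whether a chlorine or a nitrile in place of trifluoromethyl at this position would read the same. They also leave open how an amine in place of the acetamido would read.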